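Replacing the Anilide of Compound 3 with a Phenylpropyl Amide

The source may report more compounds than this note shows. Statements on the series, on what has been measured and on what is new or still open speak of the compounds shown alone.

Compound 3 `COc1ccc2nc(C)cc(OCC(=O)Nc3ccccc3Cl)c2c1` carries a 2-chlorophenyl group on its amide nitrogen. In an ADME assay on HepG2 cells (Homo sapiens) for cytotoxicity, read by trypan blue exclusion, with a stated time of 48 h, in the presence of a further agent that is not named here (a higher number here means that more compound is tolerated, a lower number that less compound is tolerated), compound 3 reaches only the limit of the assay, > 140000 nM, and no number. Two neighbours share its core. Compound 1 `COc1ccc2nc(C)cc(OCC(=O)Nc3ccccc3)c2c1` carries a plain phenyl on that nitrogen and gives 118000 nM in this assay. Compound 2 `COc1ccc2nc(C)cc(OCC(=O)Nc3cccc(Br)c3)c2c1` carries a 3-bromophenyl there, and in this assay compound 2 also gives only a limit, > 125000 nM. The steps among the three are flat: there is an at least 1.0-fold higher number from compound 1 to compound 2 (0.02 log units; that floor lies within the scatter) and an at least 1.1-fold higher number from compound 1 to compound 3 (0.07 log units; that floor lies within the scatter), while a step that the two limits leave unreadable from compound 2 to compound 3 stays unreadable because one value sits at the limit of > 125000 nM in this assay, at which 1 of the 3 values shown sits, and another at the limit of > 140000 nM in this assay, at which 1 of the 3 values shown sits. Compound 3 thus stands at the upper edge of what is visible, with nothing beyond the scatter separating it from either neighbour.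

Compound 4 `COc1ccc2nc(C)cc(OCC(=O)NCCCc3ccccc3)c2c1` arises from compound 3 by 3-phenylpropyl in place of 2-chlorophenyl on an amide-type nitrogen. For the measured compounds named here, no measured step covers this change, and the steps that are measured all stay within the scatter or cannot be read. The expectation for this assay is therefore no step beyond the scatter, an at least 1.1-fold lower number from compound 3 to compound 4 (0.04 log units; that floor lies within the scatter). Compound 4 is estimated at 125000 nM, in a range from 55000 nM to 280000 nM.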

Compound 4, half-maximal cytotoxic concentration: 50700 nM
Estimate against measurement, compound 4: 2.5-fold (0.39 log units) above; measured number outside the range, below it.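

In this assay, for the compounds shown here, the amide-type nitrogen now shows a step beyond the scatter, which none of the readable changes among the aryl groups on that nitrogen had done: 3-phenylpropyl in place of phenyl gives a 2.3-fold lower number from compound 1 to compound 4 (0.37 log units; beyond the scatter), and this is the only new step with a full size, since both of its values are numbers. Measured against the 2-chlorophenyl group, the change gives an at least 2.7-fold lower number from compound 3 to compound 4 (0.44 log units; beyond the scatter), which is a floor rather than a size because the starting value is a limit: the limit of > 140000 nM in this assay, at which 1 of the 4 values shown sits. Measured against the 3-bromophenyl group, it gives an at least 2.4-fold lower number from compound 2 to compound 4 (0.39 log units; beyond the scatter), again a floor because the starting value is a limit: the limit of > 125000 nM in this assay, at which 1 of the 4 values shown sits.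

All three steps point the same way, so the lower number holds against each of the aryl groups shown, though the true sizes of the two floors cannot be read. As far as these compounds go, it remains open how the number in this assay would respond to a benzyl or 2-phenylethyl group on that nitrogen, to a longer chain, or to a chloro on the ring of the 3-phenylpropyl group, and so whether the chain or its end ring accounts for the step.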